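The source may hold more compounds than are shown below. What is called first, only, known or untested is meant among the compounds shown, and "the series" means these compounds.

Compound 1 `COc1cc2nc(NCc3ccccc3)nc(NC3CCCCCC3)c2cc1OC` was tested in an in vitro functional assay on B300-19 cells for antagonist activity at C-C chemokine receptor type 4 (Homo sapiens), read by GTPgammaS binding, tested at 1 uM (on this read-out higher numbers stand for more inhibition at the one concentration tested (going by the name of the read-out) and lower numbers for less inhibition), where compound 1 gives 13%. Within the data shown here, the only other compound measured alongside it is compound 2 `CCNc1nc(N2CCC(N3CCCC3)CC2)nc2cc(OC)c(OC)cc12`, which in this assay gives 3%. Compound 1 therefore holds the larger of the two numbers, but the gap between compound 1 and compound 2 lies within the usual scatter of this kind of measurement, so the two cannot be separated on these data. Both values sit low, near the bottom of the scale.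

Compound 3 `COc1cc2nc(NCCCN3CCCC3=O)nc(NC3CCCCCC3)c2cc1OC` has not yet been measured. It differs from compound 1 in one place: 2-(2-oxopyrrolidin-1-yl)ethyl in place of phenyl on a saturated chain carbon bound to a nitrogen on an aromatic ring. Among the measured compounds shown here, no pair of measured compounds differing in a single place is available, so there is no measured step to lean on. Given that compound 1 gives 13% and that every number seen so far is small, the step of a number 3 percentage points lower from compound 1 to compound 3 (within the scatter) is expected to stay within the scatter, with no clear direction. Compound 3 is estimated to give 10% in this assay, within a range from -5% to 30%.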

Compound 3, a percentage reported as inhibition, at one concentration (the size of the read-out at that concentration, not a potency): 8%
Estimate against measurement, compound 3: 2 percentage points above, within the range that was stated.
By their numbers in this assay, from the lowest: compounds 2, 3 and 1 (each within the scatter of the next).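

Among these compounds, at the saturated chain carbon bound to a nitrogen on an aromatic ring, 2-(2-oxopyrrolidin-1-yl)ethyl in place of phenyl gives the first single-place step in this assay, a number 5 percentage points lower from compound 1 to compound 3 (within the scatter), so this position now has one measured change. The six-membered aromatic ring of carbon only gives way here to a five-membered non-aromatic ring with 1 hetero atom and 1 hydrogen-bond acceptor, and the data cannot separate the two compounds: compound 1 gives 13% and compound 3 gives 8%, both near the bottom of the scale. No evidence at hand bears on this result.

The compounds shown leave open what an amine, a carboxylic acid or a longer chain at this place would do to the inhibition at the one concentration tested. With compound 1 and compound 3 both small, they also leave open whether any group at this position can give a number that stands clear of the scatter.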